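From Ethylsulfanyl to Ethoxy on the Shared Core

The compounds below may be only part of what the source reports. "The series", "measured", "known", "first", "only" and "open" are said of these compounds alone.

In a functional assay on SiHa cells (Homo sapiens) for antiproliferative activity, read by CCK-8 assay, with a stated time of 72 h (a higher number here means a weaker inhibitor, a lower number a stronger inhibitor), compound 2 `CCSc1ccc(-c2cncnc2-c2cc(OC)c(OC)c(OC)c2)cc1` gives 1030 nM and compound 1 `COc1ccc(-c2cncnc2-c2cc(OC)c(OC)c(OC)c2)cc1Cl` gives 1330 nM, so the two values lie within the scatter of each other. Compound 3 `CCOc1ccc(-c2cncnc2-c2cc(OC)c(OC)c(OC)c2)cc1` carries ethoxy in place of ethylsulfanyl on an aromatic carbon, para to a large group: ethoxy in place of ethylsulfanyl on an aromatic carbon. Within the data shown here, only one measured step bears on this change, and only indirectly: a 1.3-fold lower number from compound 1 to compound 2 (0.11 log units; within the scatter), with 4-(ethylsulfanyl)phenyl in place of 3-chloro-4-methoxyphenyl. Among the measured compounds shown here, no measured pair exchanges ethylsulfanyl for ethoxy directly. Even so, that larger replacement of the aryl group stayed small, so no shift beyond the scatter is expected in this assay, in either direction. The expected step is a 1.0-fold lower number from compound 2 to compound 3 (0.01 log units; within the scatter). For compound 3 the estimated value is 1000 nM, with an expected range of 400 nM to 2500 nM.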

Compound 3, half-maximal inhibitory concentration: 640 nM
For compound 3 the middle estimate is 1.6-fold (0.19 log units) above the measured one; the measured number falls inside the stated range.
By their numbers in this assay, from the lowest: compounds 3, 2 and 1 (each within the scatter of the next, the first and the last beyond it).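

The exchange of ethylsulfanyl for ethoxy on an aromatic carbon, para to a large group, now has a direct reading: this assay shows a 1.6-fold lower number from compound 2 to compound 3 (0.21 log units; within the scatter) and so does not separate the two groups at this position. Among these compounds, the replacement of 3-chloro-4-methoxyphenyl by 4-ethoxyphenyl gives a 2.1-fold lower number from compound 1 to compound 3 (0.32 log units; beyond the scatter) and is the first step to pass beyond the scatter, though only modestly. No evidence is available to explain either step. Since 3-chloro-4-methoxyphenyl and 4-ethoxyphenyl differ in both the chlorine and the alkoxy group, the compounds shown do not say which of the two changes carries that step. Also open, on these data alone, is how the same position would respond to a different group, such as an amine, a carboxylic acid or a longer alkoxy chain.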